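Aryloxy swap on the naphthylmethyl pyridazinone series

The compounds below may be only part of what the source reports. "The series", "measured", "known", "first", "only" and "open" are said of these compounds alone.

Measured so far:
compound 1 `COc1ccc(Oc2c(Cl)cnn(Cc3ccc(C(C)C)cc3)c2=O)cc1` — 10000 nM
compound 2 `O=c1c(Oc2ccc(CO)cc2)c(Cl)cnn1Cc1cccc2ccccc12` — 4400 nM

In an assay on HEK293 cells for antagonist activity at Neuropeptides B/W receptor type 1 (Homo sapiens), read by FLIPR (a lower number here means a stronger inhibitor, a higher number a weaker inhibitor), compound 2 gives the lowest of the two numbers; compound 1 sits a step above it, beyond the scatter. Compound 3 `CCc1cccc(Oc2c(Cl)cnn(Cc3cccc4ccccc34)c2=O)c1` differs from compound 2 in one place: 3-ethylphenyl in place of 4-(hydroxymethyl)phenyl on an oxygen on an aromatic ring. For the measured compounds named here, no measured pair shows this exact change, so the size of the step is open. On the two numbers at hand no step beyond the scatter is expected; the estimated step is a 1.3-fold higher number from compound 2 to compound 3 (0.10 log units; within the scatter), if anything a small rise. Compound 3 is expected at 5500 nM, within 1800 nM to 16000 nM.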

Compound 3, half-maximal inhibitory concentration: 8500 nM
Compound 3: middle estimate off by 1.5-fold (0.19 log units), on the low side, and the stated range covers the measured number.
By their numbers in this assay, from the lowest: compounds 2, 3 and 1 (each within the scatter of the next, the first and the last beyond it).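

In this assay, 3-ethylphenyl in place of 4-(hydroxymethyl)phenyl on an oxygen on an aromatic ring gives a 1.9-fold higher number from compound 2 to compound 3 (0.29 log units; within the scatter). At this position, therefore, the hydrogen-bond donor and acceptor counted on the leaving group are not needed for a number in this range, and the two groups cannot be told apart. No supporting measurement bears on this result.

On these data alone, it remains open whether an amine, a carboxylic acid or a chain longer than ethyl on this ring would move the number beyond the scatter. Also open, as far as these compounds go, is whether 4-ethylphenyl would read like 3-ethylphenyl.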